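A few compounds are considered here, and "the series" means these few. Any claim that something is new, unique, unknown or untested is made for them only; others in the source may bear on it.

Compound 1 `COc1ccc(Nc2cc(C)nc(SCc3nc4ccccc4[nH]3)n2)cc1` is one of two compounds tested in a functional assay on ECa-109 cells (Homo sapiens) for cytotoxicity, read by MTT assay, with a stated time of 72 h; a higher number here means a weaker inhibitor, a lower number a stronger inhibitor. In this assay, among the compounds with values here, compound 1 gives 69800 nM, and among the two values shown it is the only one that is a number rather than a limit, so it stands alone on that count. Compound 2 `Cc1cc(N2CCNCC2)nc(SCc2nc3ccccc3[nH]2)n1` differs from compound 1 by piperazin-1-yl in place of (4-methoxyphenyl)amino on an aromatic carbon. For compound 2 this assay reports only a limit, > 100000 nM. The step of an at least 1.4-fold higher number from compound 1 to compound 2 (0.15 log units; that floor lies within the scatter) is bounded by the limit of > 100000 nM in this assay, at which 1 of the 2 values shown sits.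

Compound 3 `Cc1cc(Nc2ccc(F)cc2)nc(SCc2nc3ccccc3[nH]2)n1` has not yet been measured. It differs from compound 1 by fluoro in place of methoxy on an aromatic carbon. Within the data shown here, the single measured step exchanges the whole (4-methoxyphenyl)amino group for piperazin-1-yl, a change of a different kind, and so does not bear directly on a swap kept on the six-membered aromatic ring of carbon only. The expectation is therefore a step no larger than the usual scatter, a 1.0-fold higher number from compound 1 to compound 3 (0.00 log units; within the scatter), in no set direction. For compound 3 the estimate is 70000 nM, within a range from 30000 nM to 160000 nM.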

Compound 3, half-maximal inhibitory concentration: 69500 nM
For compound 3 the middle estimate is 1.0-fold (0.00 log units) above the measured one; the measured number falls inside the stated range.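

Exchanging methoxy for fluoro on the six-membered aromatic ring of carbon only, para to a large group, gives a 1.0-fold lower number from compound 1 to compound 3 (0.00 log units; within the scatter) in this assay. Within the data shown here, the earlier pair exchanged the whole (4-methoxyphenyl)amino group, so this is the first look at a change confined to the ring, and here two groups with different heavy atoms and different counts of hydrogen-bond acceptors give values within the scatter of each other. The other new step, an at least 1.4-fold lower number from compound 2 to compound 3 (0.15 log units; that floor lies within the scatter), is a floor rather than a measured size, and it is set by a limit of the assay: the limit of > 100000 nM in this assay, at which 1 of the 3 values shown sits.

With only methoxy and fluoro at this place, these compounds cannot say whether the same flat result would hold for a larger or very different group there, such as a carboxylic acid, an amine or a longer chain. They also leave open how far (4-fluorophenyl)amino and piperazin-1-yl truly lie apart, and whether any group at this place could bring a much lower number in this assay.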